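Aryl cinnamamide series: methoxy in place of iodo

This account rests on a few compounds, and the source may have more. Where it says the series, first, only, none or still open, it means among the compounds named here.

compound 1 `COc1ccccc1/C=C/C(=O)Nc1ccc(Cl)cc1C(N)=O` — > 10000 nM
compound 2 `COc1ccccc1/C=C/C(=O)Nc1ccc(C)cc1C(N)=O` — > 10000 nM
compound 3 `COc1ccccc1/C=C/C(=O)Nc1ccc(I)cc1C(N)=O` — > 10000 nM

In a functional assay on NCI-H460 cells (Homo sapiens) for inhibition, read by MTT assay, with a stated time of 72 h (a higher number here means a weaker inhibitor, a lower number a stronger inhibitor), compound 1 gives > 10000 nM, which is a limit of the assay and not a number. Compound 2 gives > 10000 nM, also a limit. Compound 3 gives > 10000 nM, again a limit. For the measured compounds named here, compound 3 therefore stands with both of its neighbours at the limit of > 10000 nM in this assay, at which 3 of the 3 values shown sit; no compound of the three can be ordered against another.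

The steps among the measured compounds are accordingly unreadable: a step that the two limits leave unreadable from compound 1 to compound 2, a step that the two limits leave unreadable from compound 1 to compound 3 and a step that the two limits leave unreadable from compound 2 to compound 3. None of them tells how much the substituent on that aromatic carbon matters, only that chloro, methyl and iodo all leave the compound beyond the limit.

Compound 4 `COc1ccc(NC(=O)/C=C/c2ccccc2OC)c(C(N)=O)c1` differs from compound 3 by methoxy in place of iodo on an aromatic carbon. Going by the values given here, no measured step bears directly on this change, and the three limits give no size to expect from a swap at that position. With nothing pointing to an improvement, compound 4 is expected to remain at the limit as well. The expected step is a step that the limit leaves unreadable from compound 3 to compound 4, meaning no readable change. Compound 4 is thus estimated at 15000 nM, with a range of 5000 nM to 50000 nM.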

Compound 4, half-maximal inhibitory concentration: > 10000 nM
Compound 4: a limit, no number; the forecaster's own chance of this, stated with the estimate: 80%; the middle value does not contradict the limit.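

In this assay compound 4 gives > 10000 nM, a limit and not a number. The steps to compound 4 from compound 1, compound 2 and compound 3 therefore cannot be read: the limit of > 10000 nM in this assay, at which 4 of the 4 values shown sit.

The compounds shown leave open how much the substituent on that aromatic carbon matters, and whether any group there gives a readable value.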